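The source may hold more compounds than are shown below. What is called first, only, known or untested is meant among the compounds shown, and "the series" means these compounds.

The shared core appears in compound 1 `O=C(CSC(=S)N[C@H]1CCOC1=O)Nc1ccccc1`, compound 2 `O=C(CSC(=S)N[C@H]1CCOC1=O)Nc1ccc(F)cc1` and compound 3 `O=C(CSC(=S)N[C@H]1CCOC1=O)Nc1ccc(C(=O)/C=C/c2ccccc2)cc1`, which differ only in the group carried on the aromatic ring of the anilide. In a functional assay on SMMC-7721 cells (Homo sapiens) for cytotoxicity, read by MTT assay, with a stated time of 72 h (on this read-out lower numbers stand for stronger inhibition and higher numbers for weaker inhibition), compound 1 gives only a limit of the assay, > 128000 nM. Compound 2 likewise gives a limit in this assay, > 128000 nM. Compound 3 too reaches only a limit there, > 128000 nM. The steps among these three are therefore unreadable: a step that the two limits leave unreadable from compound 1 to compound 2, a step that the two limits leave unreadable from compound 1 to compound 3 and a step that the two limits leave unreadable from compound 2 to compound 3. All of them rest on (the limit of > 128000 nM in this assay, at which 3 of the 3 values shown sit). Compound 3 thus stands at that limit, as do both of the others, and nothing separates it from them on the numbers shown.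

Compound 4 `O=C(CSC(=S)N[C@H]1CCOC1=O)Nc1ccc(C(=O)/C=C/c2ccc([N+](=O)[O-])cc2)cc1` differs from compound 3 in one place: nitro in place of hydrogen on an aromatic carbon. Among the compounds with values here, none of the measured steps can be read, so no size and no direction can be taken from them for this change. The expectation for compound 4 in this assay is 150000 nM, with a range from 60000 nM to 400000 nM. That estimate means an expected step that the limit leaves unreadable from compound 3 to compound 4, within the scatter, with a considerable chance that this assay again reports only a limit.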

Compound 4, half-maximal inhibitory concentration: > 128000 nM
Compound 4 ended at the assay's limit (the forecaster's own chance of this, stated with the estimate: 75%); the middle value is on the limit's open side.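

No new step can be read between compound 3 and compound 4, since the two compounds give only limits, and the nitro exchange therefore has no readable size or direction: the limit of > 128000 nM in this assay, at which 4 of the 4 values shown sit.

The compounds shown leave open how strongly any of the four acts in this assay, and whether any group on the anilide ring alters that action.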